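The source may hold more compounds than are shown below. What is called first, only, known or untested is meant among the compounds shown, and "the series" means these compounds.

Compound 1 `Cc1cc2occ(-c3nc(-c4ccccc4)c(-c4ccccc4)n3-c3ccc([N+](=O)[O-])cc3)c(=O)c2cc1Cl` gives 25000 nM in a functional assay on HepG2 cells (Homo sapiens) for inhibition, read by MTT assay, with a stated time of 72 h; a lower number here means a stronger inhibitor, a higher number a weaker inhibitor; compound 2 `Cc1cc2occ(-c3nc(-c4ccccc4)c(-c4ccccc4)n3-c3ccc(Cl)cc3)c(=O)c2cc1Cl` gives 1560 nM.

Compound 2 stands lowest of the two numbers, with compound 1 the nearest at a 16-fold lower number from compound 1 to compound 2 (1.20 log units; beyond the scatter). Compound 3 `COc1cccc(-n2c(-c3coc4cc(C)c(Cl)cc4c3=O)nc(-c3ccccc3)c2-c2ccccc2)c1` is not yet measured and differs from compound 2 in one place: 3-methoxyphenyl in place of 4-chlorophenyl on an aromatic nitrogen. Going by the values given here, the only measured step altered the group that now leaves and was large, so changes here can matter, but it does not test a methoxy group and gives no direction. A modest step is therefore expected, a 1.9-fold higher number from compound 2 to compound 3 (0.28 log units; within the scatter), of uncertain direction. Compound 3 is estimated at 3000 nM, between 800 nM and 12000 nM.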

Compound 3, half-maximal inhibitory concentration: 6250 nM
Estimate against measurement, compound 3: 2.1-fold (0.32 log units) below; measured number inside the range.
By their numbers in this assay, from the lowest: compound 2; then compound 3; then compound 1.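

In this assay, replacing 4-chlorophenyl with 3-methoxyphenyl on the aromatic nitrogen weakens inhibition (a 4.0-fold higher number from compound 2 to compound 3 (0.60 log units; beyond the scatter)), so a second change at this position also moves the number beyond the scatter. Replacing 4-nitrophenyl with 3-methoxyphenyl strengthens it (a 4.0-fold lower number from compound 1 to compound 3 (0.60 log units; beyond the scatter)), giving an order from lowest number of 4-chlorophenyl, 3-methoxyphenyl, then 4-nitrophenyl. Nothing measured here explains this order. The compounds shown leave open whether the methoxy group itself or its place on the phenyl ring sets the number, and how an amine or a carboxylic acid on that ring would compare.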